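The source may report more compounds than this note shows. Statements on the series, on what has been measured and on what is new or still open speak of the compounds shown alone.

Three compounds share one core, a chain that carries an end group on one side and a ring bearing a phenyl group on the other. In a functional assay on the whole organism (stomach) with Rattus norvegicus as the target (on this read-out higher numbers stand for an effect only at larger amounts of compound and lower numbers for an effect already at smaller amounts), compound 1 `C/N=C(/NC#N)NCCCn1nc(-c2ccccc2)ccc1=O` gives > 100 mg/kg, which is a limit of the assay rather than a number. Compound 2 `N#CNC(=N)NCCCCCn1nc(-c2ccccc2)ccc1=O` gives in this assay > 100 mg/kg, again a limit. Two of the three values sit at the limit of > 100 mg/kg in this assay, at which 2 of the 3 values shown sit. Going by the values given here, compound 3 `CC/N=C(/NC#N)NCCCn1nc(-c2ccccc2)ccc1=O` gives 78.3 mg/kg in this assay, the only real number among the three. The steps of an at least 1.2-fold lower number from compound 1 to compound 3 (0.10 log units; that floor lies within the scatter) and an at least 1.2-fold lower number from compound 2 to compound 3 (0.10 log units; that floor lies within the scatter) each have a floor that lies within the scatter, and the step that the two limits leave unreadable from compound 1 to compound 2 cannot be read at all.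

Compound 4 `CC/N=C(/NC#N)NCCCn1nc(C)ccc1=O` differs from compound 3 by methyl in place of phenyl on an aromatic carbon. Among the compounds with values here, none of the measured steps touches that aromatic carbon; all of them concern the chain and its end group, so they give no direct guidance on this change. The estimate for compound 4 is 120 mg/kg, between 40 mg/kg and 400 mg/kg, with a real chance that only a limit is reported. That estimate means an expected step of a 1.5-fold higher number from compound 3 to compound 4 (0.19 log units; within the scatter) in this assay.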

Compound 4, dose for half-maximal effect: > 100 mg/kg
Compound 4 ended at the assay's limit (the forecaster's own chance of this, stated with the estimate: 55%); the middle value lies beyond the limit too.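

Compound 4 is the only compound shown that changes the aromatic carbon, with methyl in place of phenyl while the chain and its end group stay as in compound 3. In this assay the step is an at least 1.2-fold higher number from compound 3 to compound 4 (0.10 log units; that floor lies within the scatter), so the floor alone does not establish that phenyl matters at this position, and the true size of the step stays hidden behind a limit. Compound 3 therefore remains the only compound with a real number, and the rest of the series offers no measured value to compare with it: the limit of > 100 mg/kg in this assay, at which 3 of the 4 values shown sit.

As far as these compounds go, only phenyl and methyl stand at this aromatic carbon, so it remains open how a group of intermediate size, such as ethyl or a chlorine atom, would read out here. Also open, from the compounds shown here alone, is whether a benzyl group or a longer chain at this carbon would give a real number rather than a limit.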